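Swapping fluoro for hydrogen on compound 1

A few compounds are considered here, and "the series" means these few. Any claim that something is new, unique, unknown or untested is made for them only; others in the source may bear on it.

Compound 1 `COc1cc2c(cc1CC=C(C)C)C(=O)C[C@@H](c1ccc(Oc3ccc(F)cc3)cc1)O2` gives 27%
Compound 2 `COc1ccc([C@@H]2C/C(=N/OCc3cn(-c4ccccc4CO)nn3)c3cc(CC=C(C)C)c(OC)cc3O2)cc1` gives 100%
Compound 3 `COc1ccc([C@@H]2C/C(=N/OCc3cn(-c4ccc(C(N)=O)cc4)nn3)c3cc(CC=C(C)C)c(OC)cc3O2)cc1` gives 100%

In a functional assay on A549 cells (Homo sapiens) for inhibition, read by sulforhodamine B assay, with a stated time of 48 h, tested at 50 uM (a lower number here means less inhibition of growth, a higher number more inhibition of growth at the concentration tested), compound 1 gives 27% and stands lowest of the three, beyond the scatter from compound 2 and compound 3. Compound 4 `COc1cc2c(cc1CC=C(C)C)C(=O)C[C@@H](c1ccc(Oc3ccccc3)cc1)O2` is compound 1 with hydrogen in place of fluoro on an aromatic carbon, para to a large group (hydrogen in place of fluoro on an aromatic carbon). Among the compounds with values here, the only measured step, no change at the digits printed from compound 2 to compound 3 (within the scatter), lies at another place in other compounds, and no measured pair makes this swap, so it guides only weakly. The expectation therefore starts from compound 1 at 27% and foresees no shift beyond the scatter in either direction. The expected change is a number 2 percentage points lower from compound 1 to compound 4 (within the scatter) in this estimate. For compound 4 the estimated value is 25%, with an expected range from 9% to 45% in this assay.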

Compound 4, percent growth inhibition at one concentration: 46%
Compound 4: middle estimate off by 21 percentage points, on the low side; measured number outside the range, above it.
By their numbers in this assay, from the lowest: compound 1; then compound 4; then compounds 2 and 3 (each within the scatter of the next).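

In this assay the change from 4-fluorophenoxy to phenoxy gives a number 19 percentage points higher from compound 1 to compound 4 (beyond the scatter) and so offers the first measured sign that this position affects the read-out. The fluoro is not needed for the growth inhibition seen in compound 1, since the number rises without it. No measurement shown here explains this rise.

As far as these compounds go, it remains open how a chlorine or a methoxy group at this place would compare with hydrogen and fluoro. From the compounds shown here alone, whether the same swap would move the number on the core of compound 2 is also open.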